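Aryl amide variation in a sulfonamide-benzylamide series

The compounds below may be only part of what the source reports. "The series", "measured", "known", "first", "only" and "open" are said of these compounds alone.

Measured compounds:
compound 1 `Cc1ccc(S(=O)(=O)NCc2ccc(CNC(=O)c3ccc([N+](=O)[O-])cc3)cc2)cc1`: 10 nM
compound 2 `Cc1ccc(S(=O)(=O)NCc2ccc(CNC(=O)c3ccccc3F)cc2)cc1`: 1000 nM
compound 3 `Cc1ccc(S(=O)(=O)NCc2ccc(CNC(=O)c3cccc(F)c3)cc2)cc1`: 1 nM

The three measured compounds share a core and differ only in the aryl group on the carbonyl carbon. In an assay on MDA-MB-231 cells for binding affinity to C-X-C chemokine receptor type 4 (Homo sapiens), read by immunofluorescence and microscopy, with stated times of 10 min and 30 min (on this read-out higher numbers stand for an effect only at larger amounts of compound and lower numbers for an effect already at smaller amounts), compound 3 gives the lowest number of the three; its nearest neighbour is compound 1, with a 10-fold lower number from compound 1 to compound 3 (1.00 log units; beyond the scatter), and the furthest is compound 2, with a 1000-fold lower number from compound 2 to compound 3 (3.00 log units; beyond the scatter). Compound 1 against compound 2 gives a 100-fold higher number from compound 1 to compound 2 (2.00 log units; beyond the scatter).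

Compound 4 `COc1cccc(C(=O)NCc2ccc(CNS(=O)(=O)c3ccc(C)cc3)cc2)c1` keeps the core of compound 3 and carries the change (methoxy in place of fluoro on an aromatic carbon). For the measured compounds named here, none of the measured steps swaps fluoro for methoxy, so no step bears directly on it. What the measured steps do show is that the aryl group on the carbonyl carbon moves this assay strongly, both toward lower and toward higher numbers, so a step of modest size in either direction is plausible and a flat result cannot be excluded. For compound 4 a step of a 10-fold higher number from compound 3 to compound 4 (1.00 log units; beyond the scatter) is expected, as an estimate only. Compound 4 is thus estimated at 10 nM in this assay, within 1 nM to 300 nM.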

Compound 4, effective concentration (reported as EC, without a stated level of effect): 10 nM
Beside the measured number, compound 4's estimate shows no gap at the digits printed; the measured number falls inside the stated range.
By their numbers in this assay, from the lowest: compound 3; then compounds 1 and 4 (each within the scatter of the next); then compound 2.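

Methoxy in place of fluoro on this aromatic carbon moves the number in this assay (a 10-fold higher number from compound 3 to compound 4 (1.00 log units; beyond the scatter)), so the group held here matters, not only the place it occupies. The 3-methoxyphenyl amide still stands well apart from the 2-fluorophenyl amide (a 100-fold lower number from compound 2 to compound 4 (2.00 log units; beyond the scatter)) and level with the 4-nitrophenyl amide (no change at the digits printed from compound 1 to compound 4 (within the scatter)), which shows that a 3-substituent other than fluoro can keep the number far from that of the 2-fluorophenyl amide. No measurement on hand accounts for these steps.

Open, on these data alone, is how an amine or a carboxylic acid on this aromatic carbon would read, and whether an ethoxy group or a longer chain would follow methoxy. Also open, as far as these compounds go, is how methoxy would read on the other carbons of this ring.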